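Series notes: amide aryl swap from compound 3 to compound 4

This account rests on a few compounds, and the source may have more. Where it says the series, first, only, none or still open, it means among the compounds named here.

Measured so far, in an assay on isolated protein (Mus musculus) for inhibition of IL15-IL15 receptor (Homo sapiens), read by resazurin assay, with stated times of 30 min and 2.5 days; a higher number here means a weaker inhibitor, a lower number a stronger inhibitor:
compound 1, `Cn1c(Cc2nn(C)c(=O)c3ccccc23)nnc1SCCCCCCCCCCCCCCCC(=O)Nc1ccc(Cl)cc1Cl`, gives 7300 nM.
compound 2, `CCCOc1ccc(NC(=O)CSc2nnc(Cc3nn(C)c(=O)c4ccccc34)n2C)cc1`, gives only the limit > 30000 nM.
compound 3, `CC(C)Oc1ccc(NC(=O)CSc2nnc(Cc3nn(C)c(=O)c4ccccc34)n2C)cc1`, gives only the limit > 30000 nM.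

Compound 3 stands at the limit and carries no number. For the measured compounds named here, because of the limit of > 30000 nM in this assay, at which 2 of the 3 values shown sit, the single step among measured compounds, a step that the two limits leave unreadable from compound 2 to compound 3, cannot be read. Compound 4, `CN(C(=O)CSc1nnc(Cc2nn(C)c(=O)c3ccccc23)n1C)c1ccc(Cl)cc1Cl`, differs from compound 3 by (2,4-dichlorophenyl)(methyl)amino in place of (4-isopropoxyphenyl)amino on a carbonyl carbon. Going by the values given here, no measured step bears on this change; compound 1 carries the same dichlorophenyl amide on a much longer chain and gives a number, but no step links it to compound 4. The size of a number no higher from compound 3 to compound 4 (the limit leaves the size open) is therefore an estimate without a measured anchor. Compound 4 is expected near 30000 nM, within 8000 nM to 100000 nM, with a fair chance that only a limit is reported.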

Compound 4, half-maximal inhibitory concentration: > 30000 nM
Compound 4 ended at the assay's limit; the forecaster's own chance of this, stated with the estimate: 60%; the middle value sits exactly at the limit.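

For the compounds shown here, compound 2, compound 3 and compound 4 all sit at a limit, so no step among them can be read: the limit of > 30000 nM in this assay, at which 3 of the 4 values shown sit. The compounds shown leave open whether (2,4-dichlorophenyl)(methyl)amino and (4-isopropoxyphenyl)amino on a carbonyl carbon differ at all in inhibition.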